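The source may hold more compounds than are shown below. What is called first, only, known or untested is meant among the compounds shown, and "the series" means these compounds.

Measured so far in a functional assay on H184B5F5/M10 cells (Homo sapiens) for antiproliferative activity, read by XTT assay, with a stated time of 72 h; a lower number here means a stronger inhibitor, a higher number a weaker inhibitor:
- compound 1 `COc1ccc(-c2cc3ccccc3nc2/C=C/C(=O)c2ccc(OC)c(OC)c2)cc1`: 7240 nM
- compound 2 `COc1ccc(-c2cc3ccccc3nc2/C=C/C(=O)c2ccccn2)cc1`: 4140 nM

Compound 2 holds the lowest of the two numbers in this assay, but the step of a 1.7-fold lower number from compound 1 to compound 2 (0.24 log units; within the scatter) is within the scatter, so the two compounds are not separated by this assay.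

Compound 3 `COc1ccc(-c2cc3ccccc3nc2/C=C/C(=O)c2ccc[nH]2)cc1` differs from compound 2 in one place: 1H-pyrrol-2-yl in place of pyridin-2-yl on a carbonyl carbon.

Going by the values given here, only one measured step bears on this change, the exchange on the same carbonyl carbon from compound 1 to compound 2, and it was within the scatter. It involved a different pair of groups, so it says little about a five-membered ring with one hydrogen-bond donor entering here. Nothing in the two measured compounds points in either direction; a step of no more than the scatter is expected. For compound 3 the expectation in this assay is 4500 nM, with a range of 1500 nM to 13500 nM. That corresponds to an expected step of a 1.1-fold higher number from compound 2 to compound 3 (0.04 log units; within the scatter).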

Compound 3, half-maximal inhibitory concentration: > 10000 nM
Compound 3 was reported as a limit (the forecaster's own chance of this, stated with the estimate: 5%); at least 2.2-fold (0.34 log units) between middle value and limit.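

Going by these compounds alone, exchanging pyridin-2-yl for 1H-pyrrol-2-yl gives the only step on this carbonyl carbon so far that lies beyond the scatter in this assay: an at least 2.4-fold higher number from compound 2 to compound 3 (0.38 log units; beyond the scatter). The exchange of 3,4-dimethoxyphenyl for pyridin-2-yl did not separate its two compounds, so this position is not indifferent to every change of group. Compound 3 is reported as a limit and not as a number, so the step from compound 2 is a floor: the limit of > 10000 nM in this assay, at which 1 of the 3 values shown sits.

Against the dimethoxyphenyl compound the comparison stays unresolved, with an at least 1.3-fold higher number from compound 1 to compound 3 (0.14 log units; that floor lies within the scatter). The compounds shown leave open whether the ring size or the hydrogen on the ring nitrogen matters here, a question that a furan ring or a methylated pyrrole on the same carbonyl carbon would address.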